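A few compounds are considered here, and "the series" means these few. Any claim that something is new, unique, unknown or untested is made for them only; others in the source may bear on it.

The two measured compounds share one core and differ only in the ring attached on the saturated chain carbon bound to an oxygen on an aromatic ring. Compound 1, `Cc1scnc1COc1cc(Cl)cc(-c2cc(-c3c[nH]c(=O)[nH]c3=O)cn(-c3cccnc3)c2=O)c1`, gives 22000 nM in an ADME assay on 16HBE14o- cells (Homo sapiens) for cytotoxicity, read by MTT assay, with a stated time of 72 h; a higher number here means that more compound is tolerated, a lower number that less compound is tolerated. Compound 2, `O=c1[nH]cc(-c2cc(-c3cc(Cl)cc(OCc4ocnc4C(F)(F)F)c3)c(=O)n(-c3cccnc3)c2)c(=O)[nH]1`, reaches only a limit of this assay, > 100000 nM. Compound 2 thus stands at the top of the numbers shown, where the limit of > 100000 nM in this assay, at which 1 of the 2 values shown sits, places it. Going by the values given here, the single measured step is an at least 4.5-fold higher number from compound 1 to compound 2 (0.65 log units; beyond the scatter). Compound 3, `O=c1[nH]cc(-c2cc(-c3cc(Cl)cc(OCc4scnc4C(F)(F)F)c3)c(=O)n(-c3cccnc3)c2)c(=O)[nH]1`, is the next structure, and the change from compound 2 is a group of 9 heavy atoms (4 carbon, 1 nitrogen, 3 fluorine, 1 sulfur; one five-membered aromatic ring with 2 hetero atoms) in place of a group of 9 heavy atoms (4 carbon, 1 nitrogen, 1 oxygen, 3 fluorine; one five-membered aromatic ring with 2 hetero atoms), on a saturated chain carbon bound to an oxygen on an aromatic ring. This exchange of ring type, with the trifluoromethyl kept, is contained within the measured step but was not isolated by it, so only a small move in this assay is expected, and its direction is open. For compound 3 the expected value is 70000 nM, with a range from 30000 nM to 150000 nM. The expected step is an at least 1.4-fold lower number from compound 2 to compound 3 (0.15 log units; that floor lies within the scatter).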

Compound 3, half-maximal cytotoxic concentration: > 100000 nM
Compound 3 gave a limit, no number (the forecaster's own chance of this, stated with the estimate: 45%); middle value at least 1.4-fold (0.15 log units) away from the limit.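

In this assay, the group holding sulfur and trifluoromethyl, set on a saturated chain carbon bound to an oxygen on an aromatic ring, gives an at least 4.5-fold higher number from compound 1 to compound 3 (0.65 log units; beyond the scatter). The higher number seen with compound 2 therefore does not depend on the ring oxygen of its group, since a group holding sulfur instead also gives a higher number than compound 1. Compound 2 and compound 3 both end at a limit of the assay, and the step between them cannot be read: the limit of > 100000 nM in this assay, at which 2 of the 3 values shown sit.

As far as these compounds go, how far compound 2 and compound 3 lie past that limit stays open, so any difference between their two rings remains unknown. Also open, from the compounds shown here alone, is how a nitrile or a chlorine in place of the trifluoromethyl on the same ring would read in this assay.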